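The source may report more compounds than this note shows. Statements on the series, on what has been measured and on what is new or still open speak of the compounds shown alone.

Compound 1, `COc1cc2c(cc1OC)CN(CCn1cc(COc3ccc(C)cc3)nn1)CC2`, was examined in an ADME assay on K562 cells (Homo sapiens) for cytotoxicity, read by MTT assay, with a stated time of 48 h; a lower number here means a stronger inhibitor, a higher number a weaker inhibitor. In this assay compound 1 gives > 100000 nM, which is a limit of the assay rather than a number. Its closest measured relative is compound 2, `CCc1ccc(OCc2cn(CCN3CCc4cc(OC)c(OC)cc4C3)nn2)cc1`, which carries a methyl in place of hydrogen on a saturated chain carbon bound to an aromatic carbon. In this assay compound 2 gives > 100000 nM, again a limit and not a number. The step that the two limits leave unreadable from compound 1 to compound 2 therefore cannot be read in either size or direction. Among the measured compounds shown here, that is the only measured step, and it says nothing usable: the limit of > 100000 nM in this assay, at which 2 of the 2 values shown sit. The compound still to be measured, compound 3, `COc1cc2c(cc1OC)CN(CCn1cc(COc3ccc(F)cc3)nn1)CC2`, differs from compound 1 in one place: fluoro in place of methyl on an aromatic carbon. Compound 1 itself stands only at a limit, so no number places it among others. With no readable step to lean on, no change in this assay can be expected beyond the scatter, and compound 3 is expected to sit at the limit as well. Compound 3 is thus estimated at 150000 nM, within 50000 nM to 500000 nM, an expected step that the limit leaves unreadable from compound 1 to compound 3.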

Compound 3, half-maximal inhibitory concentration: > 100000 nM
Compound 3: a limit, no number; the forecaster's own chance of this, stated with the estimate: 85%; the middle value is on the limit's open side.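

Compound 3 also stands at a limit and not at a number, so its steps from compound 1 and compound 2 cannot be read in size or direction: the limit of > 100000 nM in this assay, at which 3 of the 3 values shown sit. The compounds shown leave open whether changing the group on the aromatic ring makes any difference in this assay, and how far beyond the limit each compound lies.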